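The source may hold more compounds than are shown below. What is called first, only, known or untested is meant among the compounds shown, and "the series" means these compounds.

Compound 1 `COc1cc(C(=O)c2cn(-c3cccc([N+](=O)[O-])c3)cc2-c2ccccc2)cc(OC)c1OC`: 550 nM
Compound 2 `COc1cc(C(=O)c2cn(-c3ccc(Cl)cc3)cc2-c2ccccc2)cc(OC)c1OC`: 140 nM
Compound 3 `COc1cc(C(=O)c2cn(-c3ccccc3)cc2-c2cccc(Cl)c2)cc(OC)c1OC`: 540 nM

All three compounds were tested in a functional assay on MCF7 cells (Homo sapiens) for cytotoxicity, read by MTT assay, with a stated time of 96 h; on this read-out higher numbers stand for weaker inhibition and lower numbers for stronger inhibition. Among these three numbers compound 3 stands second highest: its value and that of compound 1 lie within the scatter of each other, while compound 2 gives a clearly lower number. Compound 4 `COc1cccc(-c2cn(-c3ccccc3)cc2C(=O)c2cc(OC)c(OC)c(OC)c2)c1` differs from compound 3 in a single place: methoxy in place of chloro on an aromatic carbon. For the measured compounds named here, no measured pair swaps these two groups on this ring. Going by the values given here, the only measured single-point step, a 3.9-fold lower number from compound 1 to compound 2 (0.59 log units; beyond the scatter), concerns the ring attached to the aromatic nitrogen, not the ring changed here, so it offers no direct guide to the present exchange. Among the compounds with values here, with no closer precedent, compound 4 is expected to stay near compound 3, and the step of a 1.1-fold higher number from compound 3 to compound 4 (0.05 log units; within the scatter) is expected to lie within the scatter rather than beyond it. The estimate for compound 4 is therefore 600 nM, with a range from 200 nM to 1800 nM.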

Compound 4, half-maximal inhibitory concentration: 180 nM
For compound 4 the middle estimate is 3.3-fold (0.52 log units) above the measured one, and the stated range ends above it.
By their numbers in this assay, from the lowest: compounds 2 and 4 (each within the scatter of the next); then compounds 3 and 1 (each within the scatter of the next).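

In this assay, methoxy in place of chloro on this aromatic carbon gives a 3.0-fold lower number from compound 3 to compound 4 (0.48 log units; beyond the scatter). For the compounds shown here, the earlier step concerned only the ring on the aromatic nitrogen, so this is the first sign that the group on the other ring, meta to a large group, also shifts the number. The exchange adds one heavy atom and one hydrogen-bond acceptor, yet no measurement at hand explains the shift.

The compounds shown leave open whether the gain belongs to methoxy itself, since a longer ether such as ethoxy, a hydroxyl or an amine at this carbon would test how much the group's identity matters. They also leave open whether methoxy gives a similar step at other places on this ring, or alongside a 4-chlorophenyl on the aromatic nitrogen.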